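A few compounds are considered here, and "the series" means these few. Any claim that something is new, unique, unknown or untested is made for them only; others in the source may bear on it.

Compound 2 `COc1ccc(N/C=C\C(=O)c2nc(-c3ccc(F)cc3)n3ccccc23)cc1OC` was run in a functional assay on BT-474 cells (Homo sapiens) for cytotoxicity, read by MTT assay, with a stated time of 48 h; a higher number here means a weaker inhibitor, a lower number a stronger inhibitor. In this assay compound 2 reports only a limit of the assay, > 30000 nM. Compound 2 thus sits at the limit of > 30000 nM in this assay, at which 1 of the 2 values shown sits. Compound 1 `COc1ccc(-c2nc(C(=O)/C=C\Nc3ccc(Cl)cc3)c3ccccn23)cc1` carries the 4-chlorophenyl on the amine nitrogen and gives 37300 nM in this assay, a weak inhibition. Compound 3 `O=C(/C=C\Nc1ccc(Cl)cc1)c1nc(-c2ccc(F)cc2)n2ccccc12` differs from compound 2 by 4-chlorophenyl in place of 3,4-dimethoxyphenyl on an amine nitrogen. Going by the values given here, no measured pair isolates this change. The step that the limit leaves unreadable from compound 2 to compound 3 is expected to stay within the scatter, with no gain in potency anticipated. Compound 3 is estimated at 35000 nM, expected to fall between 15000 nM and 90000 nM.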

Compound 3, half-maximal inhibitory concentration: 7030 nM
Beside the measured number, compound 3's estimate is 5.0-fold (0.70 log units) above it, outside the stated range (below it).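

In this assay the swap to 4-chlorophenyl from 3,4-dimethoxyphenyl on the amine nitrogen gives an at least 4.2-fold lower number from compound 2 to compound 3 (0.63 log units; beyond the scatter) and shows that this position can move the number. Compound 2 stands at a limit of the assay, so this step is only a bound: the limit of > 30000 nM in this assay, at which 1 of the 3 values shown sits. Going by these compounds alone, with 4-chlorophenyl kept on the amine nitrogen, fluoro in place of methoxy on an aromatic carbon gives a 5.3-fold lower number from compound 1 to compound 3 (0.72 log units; beyond the scatter) and is the first fully numeric step.

Open, from the compounds shown here alone, is how a carboxylic acid or an amine on that aromatic carbon would compare with fluoro. Also open, going by these compounds, is whether an unsubstituted phenyl on the amine nitrogen would keep the lower number.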